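The source may hold more compounds than are shown below. What is called first, only, known or untested is meant among the compounds shown, and "the series" means these compounds.

Measured so far in a functional assay on A549 cells (Homo sapiens) for inhibition, read by sulforhodamine B assay, with a stated time of 72 h; a lower number here means a stronger inhibitor, a higher number a weaker inhibitor:
- compound 1 `COc1ccc(CNC(=O)c2c(N)sc(-c3ccc(Cl)cc3)c2-c2ccc(Cl)cc2)cc1`: 18200 nM
- compound 2 `Nc1sc(-c2ccc(Cl)cc2)c(-c2ccc(Cl)cc2)c1C(=O)N1CCC(=O)CC1=O`: 4090 nM
- compound 3 `Nc1sc(-c2ccc(Cl)cc2)c(-c2ccc(Cl)cc2)c1C(=O)NC1CC1`: 1950 nM

Compound 3 gives the lowest number of the three; compound 2 sits nearest, and compound 1 is the furthest away. The three compounds share the same core and differ only in the group attached to the carbonyl carbon.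

Compound 4 `Nc1sc(-c2ccc(Cl)cc2)c(-c2ccc(Cl)cc2)c1C(=O)N1CCCCC1` carries the change (piperidin-1-yl in place of cyclopropylamino on a carbonyl carbon). The step that bears most directly on it is a 2.1-fold lower number from compound 2 to compound 3 (0.32 log units; beyond the scatter), since compound 2 also has a ring nitrogen rather than an amide hydrogen on that carbonyl carbon. That step was modest. The larger step of a 9.3-fold lower number from compound 1 to compound 3 (0.97 log units; beyond the scatter) shows how much the group on this carbonyl carbon can matter, while a 4.4-fold lower number from compound 1 to compound 2 (0.65 log units; beyond the scatter) shows that a ring attached through its nitrogen is still clearly better than the group of compound 1.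

Taken together, a modest rise in number from compound 3 to compound 4 is expected, roughly of the size seen between compound 3 and compound 2, though it could also stay within the scatter. The expected step is a 1.8-fold higher number from compound 3 to compound 4 (0.25 log units; within the scatter). Compound 4 is estimated at 3500 nM in this assay, with a range from 1500 nM to 9000 nM.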

Compound 4, half-maximal inhibitory concentration: 4620 nM
Beside the measured number, compound 4's estimate is 1.3-fold (0.12 log units) below it, and the stated range covers the measured number.
By their numbers in this assay, from the lowest: compound 3; then compounds 2 and 4 (each within the scatter of the next); then compound 1.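

In this assay, the change gives a 2.4-fold higher number from compound 3 to compound 4 (0.37 log units; beyond the scatter) and so shows that the cyclopropylamino group of compound 3 holds a real edge over a plain ring attached through its nitrogen, an edge that compound 2 alone hinted at only narrowly. The two ring groups can now be set side by side: a 1.1-fold higher number from compound 2 to compound 4 (0.05 log units; within the scatter) lies within the scatter, so 2,4-dioxopiperidin-1-yl and piperidin-1-yl cannot be told apart at this carbonyl carbon, and the two ring carbonyls of compound 2 make no readable difference here. Even so, a 3.9-fold lower number from compound 1 to compound 4 (0.60 log units; beyond the scatter) leaves the (4-methoxybenzyl)amino group of compound 1 as the weakest of the four groups, with every step away from it beyond the scatter.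

The change removes the amide hydrogen and swaps the three-membered ring for a six-membered one in a single move, so the compounds cannot say which part accounts for the higher number, and no measurement offered here gives a reason for it. A cyclopropyl(methyl)amino group, which keeps the three-membered ring without the amide hydrogen, and a cyclohexylamino group, which keeps the amide hydrogen with a six-membered ring, would pull these two parts apart.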